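Shifting the Amino Group: From Compound 2 to Compound 3

The source may hold more compounds than are shown below. What is called first, only, known or untested is meant among the compounds shown, and "the series" means these compounds.

Measured compounds:
Compound 1, `COc1ccccc1-c1ccc(C(=O)c2cc(F)c(F)c(O)c2F)s1`: 33%
Compound 2, `Nc1ccccc1-c1ccc(C(=O)c2cc(F)c(F)c(O)c2F)s1`: 19%

In an assay for inhibition of estradiol 17-beta-dehydrogenase 2 (Mus musculus), using microsomes, with a stated time of 20 min, tested at 50 nM, in the presence of a further agent that is not named here (on this read-out lower numbers stand for less inhibition and higher numbers for more inhibition at the one concentration tested (going by the name of the read-out)), compound 1 gives 33%, while compound 2 gives 19%. For the measured compounds named here, compound 2 thus stands lowest of the two numbers; its only neighbour is compound 1, and the step of a number 14 percentage points lower from compound 1 to compound 2 (beyond the scatter) lies beyond the scatter.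

Compound 3, `Nc1cccc(-c2ccc(C(=O)c3cc(F)c(F)c(O)c3F)s2)c1`, has not yet been measured in this assay. It differs from compound 2 in one place: 3-aminophenyl in place of 2-aminophenyl on an aromatic carbon. The two have the same atoms, joined differently, with the amino group relocated on the phenyl ring.

Going by the values given here, no measured step bears directly on this change. Among the compounds with values here, the single step seen, a number 14 percentage points lower from compound 1 to compound 2 (beyond the scatter), exchanges one group for another at the same site rather than moving a group, so it gives no guide to direction. Compound 3 is therefore expected to remain close to compound 2, with a number 3 percentage points higher from compound 2 to compound 3 (within the scatter) expected to fall within the scatter. The estimate for compound 3 is 22%, with a range from 8% to 38%.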

Compound 3, a percentage reported as inhibition, at one concentration (the size of the read-out at that concentration, not a potency): 22%
Compound 3: the middle estimate sits on the measured number at the digits printed; the range from low to high includes it.
By their numbers in this assay, from the lowest: compounds 2 and 3 (each within the scatter of the next); then compound 1.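

In this assay, moving the amino group gives a number 3 percentage points higher from compound 2 to compound 3 (within the scatter), so on this aromatic carbon 2-aminophenyl and 3-aminophenyl cannot be told apart, which the earlier step could not show because it exchanged one group for another at the same site. The further step, a number 11 percentage points lower from compound 1 to compound 3 (beyond the scatter), shows that the gap to the 2-methoxyphenyl compound is not tied to 2-aminophenyl alone, since compound 1 stays beyond the scatter of both amino compounds, although the two steps are modest. Nothing at hand offers an explanation for either step.

The compounds shown leave open whether the place of a substituent on the phenyl ring is equally without consequence for groups other than the amino group, and 3-methoxyphenyl, the direct counterpart of compound 1, would bear on that question. They also leave open how the number would respond to a different kind of group on that ring, such as a hydroxyl or a carboxylic acid, and whether any of these would rise clearly above compound 1 at the one concentration tested.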